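Series notes: aminothiophene ketones, step to compound 4

This account rests on a few compounds, and the source may have more. Where it says the series, first, only, none or still open, it means among the compounds named here.

Measured so far:
- compound 1 `COCCOc1ccc(-c2sc(N)c(C(=O)c3ccc(Cl)cc3)c2CC(C)(C)C)cc1`: 1%
- compound 2 `CC(C)(C)Cc1c(-c2ccc(OC(F)(F)F)cc2)sc(N)c1C(=O)c1ccc(Cl)cc1`: 1%
- compound 3 `CC(C)(C)Cc1c(-c2ccccc2)sc(N)c1C(=O)c1ccc(Cl)cc1`: 1%

All three were run in an assay on CHO cells for displacement of a labelled ligand from adenosine receptor A3 (Homo sapiens), read by scintillation counting, tested at 10 uM; a lower number here means less inhibition, a higher number more inhibition at the concentration tested (going by the name of the read-out). Compound 1 gives 1%, compound 2 gives 1% and compound 3 gives 1%. Compound 3 therefore stands level with compounds 1 and 2 at the digits printed; nearest is compound 1, furthest compound 2, and neither gap exceeds the scatter. The steps among the measured compounds were no change at the digits printed from compound 1 to compound 2 (within the scatter), no change at the digits printed from compound 1 to compound 3 (within the scatter) and no change at the digits printed from compound 2 to compound 3 (within the scatter), each changing only the substituent on the aromatic ring attached to the core and each without effect.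

Compound 4 `Cc1ccc(C(=O)c2c(N)sc(-c3ccccc3)c2CC(C)(C)C)cc1` differs from compound 3 as follows: methyl in place of chloro on an aromatic carbon, on the ring carrying the carbonyl, para to a large group. For the measured compounds named here, no measured step alters this ring, so the three steps above bear only indirectly: they show the series sitting at a flat, low read-out regardless of substituent change. On that basis a step of a number 1 percentage points higher from compound 3 to compound 4 (within the scatter) is expected, without direction beyond the scatter. The estimate for compound 4 in this assay is 2%, expected within -8% to 12%.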

Compound 4, a percentage reported as inhibition, at one concentration (the size of the read-out at that concentration, not a potency): 1%
Compound 4: the middle estimate sits 1 percentage points above what was measured; the measured number falls inside the stated range.
By their numbers in this assay, from the lowest: compounds 1, 2, 3 and 4 (each within the scatter of the next).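

In this assay, methyl in place of chloro on the ring carrying the carbonyl, para to a large group, gives no change at the digits printed from compound 3 to compound 4 (within the scatter). For the compounds shown here, this is the first step at this ring, so 4-chlorophenyl to 4-methylphenyl joins the changes on the ring attached to the core in having no readable effect, and the flat picture now covers both aromatic rings across compounds 1, 2, 3 and 4. No measurement here offers an explanation for this result.

With all four compounds at the same low read-out, the compounds shown cannot tell whether this position matters at all for the read-out at the concentration tested. As far as these compounds go, whether an amine or a carboxylic acid in place of the methyl of compound 4 would give a different read-out remains open.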